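Ring Stereochemistry and Rat Microsomal Clearance

A few compounds are considered here, and "the series" means these few. Any claim that something is new, unique, unknown or untested is made for them only; others in the source may bear on it.

The three measured compounds were all run in an ADME assay on liver for metabolic stability, with Liver microsome (Rattus norvegicus) as the target, read by LC-MS, using microsomes, with a stated time of 5 h; on this read-out lower numbers stand for slow clearance and higher numbers for fast clearance. Compound 1, `C[C@]1(O)C[C@@](c2cccc(C(F)(F)F)c2)([C@H](O)c2ccccn2)C1`, gives 317 mL/min/kg in this assay. Compound 2, `C[C@]1(c2ccc(OC(F)(F)F)cc2)C[C@@](O)(c2ccccn2)CO1`, gives 150 mL/min/kg in this assay. Compound 3, `C[C@]1(O)C[C@@](c2cc(C(F)(F)F)ccn2)([C@H](O)c2ccccn2)C1`, gives 117 mL/min/kg in this assay. Compound 3 sits at the low end of these three numbers: the number for compound 2 lies within the usual scatter of it, whereas the number for compound 1 lies beyond the scatter above it. Among the compounds with values here, no pair among the three differs in a single place, so no isolated step between measured compounds can be read from them.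

Compound 4, `C[C@]1(O)C[C@](c2cc(C(F)(F)F)ccn2)([C@H](O)c2ccccn2)C1`, has not yet been measured in this assay. It relates to compound 3 as follows: the two compounds have the same atoms and bonds and differ only in configuration as drawn: 2 of 3 stereo elements differ; a stereocentre at a saturated ring carbon is drawn R in compound 3 and S in compound 4; a stereocentre at a saturated ring carbon is drawn s in compound 3 and r in compound 4. Within the data shown here, nothing among the measured compounds shows how such a change in configuration at two saturated ring carbons affects the read-out in this assay. With the same atoms and bonds retained, the step of a 1.2-fold higher number from compound 3 to compound 4 (0.08 log units; within the scatter) is expected to be small, most likely within the scatter, and in no firm direction. On that basis compound 4 is estimated to give about 140 mL/min/kg in this assay, with a range from 65 mL/min/kg to 300 mL/min/kg.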

Compound 4, clearance: 100 mL/min/kg
Estimate against measurement, compound 4: 1.4-fold (0.15 log units) above; low and high end bracket the measured number.
By their numbers in this assay, from the lowest: compounds 4, 3 and 2 (each within the scatter of the next); then compound 1.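

In this assay, within the data shown here, the change of configuration at the two saturated ring carbons gives a 1.2-fold lower number from compound 3 to compound 4 (0.07 log units; within the scatter), the first step in this set that isolates a single kind of change. This step can be read as a matter of configuration alone, because nothing else separates the pair: the fact that compounds 3 and 4 differ only in the configuration as drawn. Among these compounds, earlier, no pair could speak to this question, whereas this pair shows that, with these substituents, the two drawn arrangements at these ring carbons give numbers within the usual scatter of each other, so this assay does not tell them apart.

The compounds shown leave open whether the third stereo element, which is the same in compound 3 and compound 4, would behave in the same way if it were changed, since no compound here varies it. They also leave open whether configuration at the two ring carbons would remain without a clear effect on this read-out if the trifluoromethyl group gave way to a carboxylic acid or an amine, or if the hydroxyl group gave way to a longer chain.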